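The source may hold more compounds than are shown below. What is called first, only, known or untested is meant among the compounds shown, and "the series" means these compounds.

Compound 1 `COc1cc(-c2cc(/C=C/C(=O)c3ccc(N)cc3)[nH]n2)cc(OC)c1OC`: 23700 nM
Compound 2 `COc1cc(-c2cc(/C=C/C(=O)c3ccc(Cl)c(Cl)c3)[nH]n2)cc(OC)c1OC`: > 100000 nM, a limit of the assay
Compound 3 `COc1ccc(C(=O)/C=C/c2cc(-c3cc(OC)c(OC)c(OC)c3)n[nH]2)cc1OC`: 49900 nM

All three measured compounds share one core and differ only in the aromatic ring that sits on the carbonyl carbon. In a functional assay on OVCAR-4 cells (Homo sapiens) for inhibition, read by sulforhodamine B assay, with a stated time of 48 h (on this read-out higher numbers stand for lower toxicity in this test and lower numbers for higher toxicity in this test), compound 3 stands highest of the two numbers that were obtained; its nearest neighbour is reached by the step of a 2.1-fold higher number from compound 1 to compound 3 (0.32 log units; beyond the scatter). The value of compound 2 is a limit of the assay and not a number. The comparison an at least 2.0-fold lower number from compound 2 to compound 3 (0.30 log units; that floor lies within the scatter) therefore rests on a floor, and the larger step of an at least 4.2-fold higher number from compound 1 to compound 2 (0.62 log units; beyond the scatter) is also only a lower bound.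

Compound 4 `COc1ccc(C(=O)/C=C/c2cc(-c3cc(OC)c(OC)c(OC)c3)n[nH]2)cc1` has not been measured. It differs from compound 3 by hydrogen in place of methoxy on an aromatic carbon. Among the compounds with values here, the steps that bear on this change are the ones that alter the same ring on the carbonyl carbon, a 2.1-fold higher number from compound 1 to compound 3 (0.32 log units; beyond the scatter) and an at least 2.0-fold lower number from compound 2 to compound 3 (0.30 log units; that floor lies within the scatter), both modest or undecided, and the larger but bounded an at least 4.2-fold higher number from compound 1 to compound 2 (0.62 log units; beyond the scatter). Removing one methoxy group is a smaller change than swapping the whole substitution pattern, so the expected step in this assay is small, a 1.2-fold lower number from compound 3 to compound 4 (0.10 log units; within the scatter), with no clear direction. Compound 4 is thus estimated at 40000 nM, expected to fall between 15000 nM and 110000 nM.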

Compound 4, concentration lethal to 50% of the cells: > 100000 nM
Compound 4 ended at the assay's limit (the forecaster's own chance of this, stated with the estimate: 25%); middle value at least 2.5-fold (0.39 log units) away from the limit.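

In this assay, the value of compound 4 is a limit of the assay and not a number, and compound 4 now sits at the same limit as compound 2: the limit of > 100000 nM in this assay, at which 2 of the 4 values shown sit. Taking one methoxy group off the 3,4-dimethoxyphenyl ring gives an at least 2.0-fold higher number from compound 3 to compound 4 (0.30 log units; that floor lies within the scatter), so this single position has not yet shown a change that clearly stands beyond the scatter, although the true step could be larger than that floor. The comparison with the amino compound is firmer: methoxy on that ring carbon gives an at least 4.2-fold higher number from compound 1 to compound 4 (0.62 log units; beyond the scatter), which shows that the second methoxy group of compound 3 is not needed for a step beyond the scatter from compound 1, and this too is only a lower bound.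

Going by these compounds, the step between compound 2 and compound 4 cannot be read, as both rest on the limit, so the order of these two stays unknown. On these data alone, it also remains open whether a hydroxy group or a longer ethoxy chain in the place of the lost methoxy group would give a value that can be read as a number in this assay.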